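Swapping methyl for bromo on a soluble pyrazole amide

A few compounds are considered here, and "the series" means these few. Any claim that something is new, unique, unknown or untested is made for them only; others in the source may bear on it.

Measured so far:
compound 1 `CCCS(=O)(=O)Nc1ccc(Cl)c(C(=O)Nc2cnc3[nH]ncc3c2)c1F` gives 48 ug/mL in a physicochemical assay for solubility, read by HPLC, in phosphate buffer, with a stated time of 24 h, at pH 7.4; a lower number here means a less soluble compound, a higher number a more soluble compound
compound 2 `CCCS(=O)(=O)Nc1ccc(F)c(C(=O)Nc2cnc3[nH]nc(C)c3c2)c1F` gives 740 ug/mL in this assay
compound 3 `CCCS(=O)(=O)Nc1ccc(F)c(C(=O)Nc2cnc3[nH]cc(Br)c3c2)c1F` gives < 1 ug/mL in this assay, which is a limit of the assay, not a number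

Compound 2 has the highest number of the two that were measured, with compound 1 standing well below it, a gap beyond the scatter. Compound 4 `CCCS(=O)(=O)Nc1ccc(F)c(C(=O)Nc2cnc3[nH]nc(Br)c3c2)c1F` differs from compound 2 by one change: bromo in place of methyl on an aromatic carbon. Going by the values given here, no step between measured compounds matches this change, so the direction must be guessed; compound 3 carries a bromo group on a different core and sits at the limit (the limit of < 1 ug/mL in this assay, at which 1 of the 3 values shown sits), which points toward lower solubility. A drop beyond the scatter is expected, a 12-fold lower number from compound 2 to compound 4 (1.09 log units; beyond the scatter). Compound 4 is estimated at 60 ug/mL, within 5 ug/mL to 400 ug/mL.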

Compound 4, solubility: 3 ug/mL
Estimate against measurement, compound 4: 20-fold (1.30 log units) above; the measured number lies below the stated range.
By their numbers in this assay, from the lowest: compound 4; then compound 1; then compound 2. At a limit, below all of these: compound 3.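

Going by these compounds alone, exchanging methyl for bromo on this aromatic carbon gives the first one-place comparison in this assay, and it is a large one: a 250-fold lower number from compound 2 to compound 4 (2.39 log units; beyond the scatter). The two groups match in their counts of heavy atoms, hydrogen-bond donors and acceptors, and in net charge, so these counts do not separate them. Compound 3, the other bromo compound, has a different core and gives a limit, not a number: the limit of < 1 ug/mL in this assay, at which 1 of the 4 values shown sits.

The compounds shown leave open how an amine, a carboxylic acid or a longer chain on this carbon would compare with methyl and bromo. Going by these compounds, whether a step of this size recurs on another core also remains unknown.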